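The source may hold more compounds than are shown below. What is called first, only, known or untested is meant among the compounds shown, and "the series" means these compounds.

Compound 1 `O=c1c2ccccc2[se]n1-c1nnc(-c2cccc([N+](=O)[O-])c2)s1` and compound 2 `O=c1c2ccccc2[se]n1-c1nnc(-c2cc([N+](=O)[O-])cc([N+](=O)[O-])c2)s1` share the same core and differ only in the number of nitro groups on the outer ring. In a functional assay on MCF7 cells (Homo sapiens) for antiproliferative activity, read by CCK-8 assay, with a stated time of 48 h (a higher number here means a weaker inhibitor, a lower number a stronger inhibitor), compound 1 gives 29200 nM, and compound 2 gives 37800 nM. The step of a 1.3-fold higher number from compound 1 to compound 2 (0.11 log units; within the scatter) is too small to count as a real difference, so compound 1 stands at the lower of two numbers that are, in effect, equivalent.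

Compound 3 `Cc1cccc(-c2nnc(-n3[se]c4ccccc4c3=O)s2)c1` differs from compound 1 by methyl in place of nitro on an aromatic carbon. Among the measured compounds shown here, the only measured step, a 1.3-fold higher number from compound 1 to compound 2 (0.11 log units; within the scatter), concerns adding a second nitro rather than exchanging one for a methyl, so it bears on the question only loosely; what it does show is that changing the substitution on this ring moved this assay by no more than the scatter. On that basis compound 3 is expected to sit close to compound 1, with an expected step of a 1.0-fold higher number from compound 1 to compound 3 (0.01 log units; within the scatter). The estimate for compound 3 in this assay is 30000 nM, within a range from 12000 nM to 75000 nM.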

Compound 3, half-maximal inhibitory concentration: 19900 nM
For compound 3 the middle estimate is 1.5-fold (0.18 log units) above the measured one; low and high end bracket the measured number.
By their numbers in this assay, from the lowest: compounds 3, 1 and 2 (each within the scatter of the next).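

Exchanging the nitro group for a methyl on this ring gives a 1.5-fold lower number from compound 1 to compound 3 (0.17 log units; within the scatter) in this assay. Among the compounds shown here, the earlier pair showed only that a second nitro group could be added without a change beyond the scatter, whereas compound 3 has no nitro group at all. In this pair, then, the nitro group can give way to a methyl, a smaller group with no hydrogen-bond acceptors, and the two compounds still cannot be told apart in this assay, though no measurement at hand explains why.

Still open, as far as these compounds go, is whether a different kind of group at this place, such as an amine or a carboxylic acid, would move the number beyond the scatter. The same question applies to a longer chain, such as a butyl group.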